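This account rests on a few compounds, and the source may have more. Where it says the series, first, only, none or still open, it means among the compounds named here.

Measured compounds:
compound 1, `Cc1ccc(C2=NN(c3nc(-c4ccc(C(F)(F)F)cc4)cs3)C(c3cccs3)C2)cc1`: 31500 nM
compound 2, `Clc1ccc(C2=NN(c3nc(-c4ccccc4)cs3)C(c3cccs3)C2)cc1`: 190 nM

Two analogues on a shared core have been run in a functional assay on MCF7 cells (Homo sapiens) for antiproliferative activity, read by MTT assay, with a stated time of 48 h; on this read-out higher numbers stand for weaker inhibition and lower numbers for stronger inhibition. Compound 1 `Cc1ccc(C2=NN(c3nc(-c4ccc(C(F)(F)F)cc4)cs3)C(c3cccs3)C2)cc1` gives 31500 nM. Compound 2 `Clc1ccc(C2=NN(c3nc(-c4ccccc4)cs3)C(c3cccs3)C2)cc1` gives 190 nM, the lower of the two numbers, and the gap between the two lies well beyond the scatter. The two compounds differ in more than one place, so the values alone do not show which change carries that gap.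

Compound 3 `FC(F)(F)c1ccc(-c2csc(N3N=C(c4ccc(Cl)cc4)CC3c3cccs3)n2)cc1` is next. It differs from compound 2 by trifluoromethyl in place of hydrogen on an aromatic carbon. Among the compounds with values here, no measured pair isolates this change. Within the data shown here, the only measured compound bearing a trifluoromethyl on that ring is compound 1, with its value of 31500 nM, and on that ground a step toward a higher number in this assay is expected from compound 2 to compound 3, though other changes also separate compound 1 from compound 2, which leaves the size uncertain. Compound 3 is expected at 2000 nM, within 300 nM to 15000 nM. This corresponds to an expected step of an 11-fold higher number from compound 2 to compound 3 (1.02 log units; beyond the scatter).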

Compound 3, half-maximal inhibitory concentration: 160 nM
Estimate against measurement, compound 3: 13-fold (1.10 log units) above; the measured number lies below the stated range.
By their numbers in this assay, from the lowest: compounds 3 and 2 (each within the scatter of the next); then compound 1.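

In this assay, exchanging hydrogen for trifluoromethyl on the six-membered aromatic ring, para to a large group, leaves the read-out within the scatter (a 1.2-fold lower number from compound 2 to compound 3 (0.07 log units; within the scatter)), so phenyl and 4-(trifluoromethyl)phenyl cannot be told apart with chloro held on the other aryl ring. With 4-(trifluoromethyl)phenyl held constant, chloro in place of methyl gives a large step (a 200-fold lower number from compound 1 to compound 3 (2.29 log units; beyond the scatter)), and this single-place comparison ties the weak value of compound 1 to methyl rather than chloro in this pair.

Open, going by these compounds, is whether that methyl-to-chloro step keeps its size with plain phenyl in place of 4-(trifluoromethyl)phenyl, and how a methoxy group, an amine or a bromine would read at the chloro position. The data shown offer no measurement that explains either step.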